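Chloro substitution on the aromatic ring of compound 1

The compounds below may be only part of what the source reports. "The series", "measured", "known", "first", "only" and "open" are said of these compounds alone.

Measured compounds:
compound 1 `CC(C)(C)OC(=O)/C=C1/C(=O)Nc2ccccc21` gives 87.3% in a functional assay on SK-BR-3 cells (Homo sapiens) for inhibition, read by CCK-8 assay, with a stated time of 72 h, tested at 20 uM; a lower number here means less inhibition of growth, a higher number more inhibition of growth at the concentration tested
compound 2 `COc1ccc2c(c1)NC(=O)/C2=C/C(=O)OC(C)(C)C` gives 87% in this assay
compound 3 `COc1cccc2c1NC(=O)/C2=C/C(=O)OC(C)(C)C` gives 87.7% in this assay

Compound 1 sits second highest of the three numbers, with compound 2 the nearest and compound 3 the furthest, both differences within the scatter. Compound 4 `CC(C)(C)OC(=O)/C=C1/C(=O)Nc2ccc(Cl)cc21` differs from compound 1 by chloro in place of hydrogen on an aromatic carbon, on an aromatic carbon of the six-membered carbon-only ring, meta to a fused ring and para to a fused ring. The two steps that bear on this, a number 0.3 percentage points lower from compound 1 to compound 2 (within the scatter) and a number 0.4 percentage points higher from compound 1 to compound 3 (within the scatter), are both aromatic substitutions on the same core and both stayed within the scatter. Among the compounds with values here, no measured step with chloro exists, so this group is untested here. A step of a number 0.3 percentage points lower from compound 1 to compound 4 (within the scatter) in this assay is therefore expected, none beyond the scatter. Compound 4 is estimated at 87%, between 76% and 95%.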

Compound 4, percent growth inhibition at one concentration: 87.6%
Compound 4: middle estimate off by 0.6 percentage points, on the low side; low and high end bracket the measured number.
By their numbers in this assay, from the lowest: compounds 2, 1, 4 and 3 (each within the scatter of the next).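

The ring carbon substituted in compound 4 carries no substituent in compounds 2 or 3, so this is a new position as well as a new group. In this assay, chloro in place of hydrogen here gives a number 0.3 percentage points higher from compound 1 to compound 4 (within the scatter), so this position accepts chloro without a change beyond the scatter. Nothing available accounts for this result.

Going by these compounds, whether a larger or differently charged group, such as an amine or a carboxylic acid, would be accepted on this carbon remains open. A single-concentration reading also leaves any differences in potency among these compounds unresolved.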